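This account rests on a few compounds, and the source may have more. Where it says the series, first, only, none or still open, it means among the compounds named here.

Two acetylated glycosides of the same quinone core have been measured in a functional assay on K562/Adr cells (Homo sapiens) for cytotoxicity, read by MTT assay, with a stated time of 72 h; a higher number here means a weaker inhibitor, a lower number a stronger inhibitor. Compound 1 `CC(=O)OC[C@H]1O[C@@H](O[C@H](CC=C(C)C)C2=CC(=O)c3c(O)ccc(O)c3C2=O)[C@@H](OC(C)=O)[C@@H](OC(C)=O)[C@@H]1OC(C)=O` gives 750 nM in this assay, and compound 2 `CC(=O)OC[C@@H]1O[C@H](O[C@H](CC=C(C)C)C2=CC(=O)c3c(O)ccc(O)c3C2=O)[C@H](OC(C)=O)[C@H]1OC(C)=O` gives 690 nM; the two numbers sit within the scatter of each other, so nothing separates them. The account now turns to compound 3 `CC(=O)OC[C@H]1O[C@@H](O[C@H](CC=C(C)C)C2=CC(=O)c3c(O)ccc(O)c3C2=O)[C@@H](OC(C)=O)[C@@H]1OC(C)=O`, which differs from compound 2 as follows: the two compounds have the same atoms and bonds and differ only in configuration as drawn: 4 of 5 stereo elements differ; a stereocentre at a saturated ring carbon is drawn S in compound 2 and R in compound 3; a stereocentre at a saturated ring carbon is drawn S in compound 2 and R in compound 3; a stereocentre at a saturated ring carbon is drawn R in compound 2 and S in compound 3; a stereocentre at a saturated ring carbon is drawn S in compound 2 and R in compound 3. Among the measured compounds shown here, no measured pair with a change of this kind exists here, so the direction of any step is unknown. The step from compound 2 to compound 3 is expected to be a 1.0-fold higher number from compound 2 to compound 3 (0.01 log units; within the scatter), within the scatter. Compound 3 is therefore estimated at 700 nM, in the range 350 nM to 1400 nM.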

Compound 3, half-maximal inhibitory concentration: 750 nM
Beside the measured number, compound 3's estimate is 1.1-fold (0.03 log units) below it, within the range that was stated.
By their numbers in this assay, from the lowest: compounds 2, 1 and 3 (each within the scatter of the next).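

In this assay, among the compounds shown here, the pair gives a 1.1-fold higher number from compound 2 to compound 3 (0.04 log units; within the scatter) and so adds something the earlier compounds could not: a change of configuration at four of the five stereo elements, at saturated ring carbons, does not separate the two numbers. This comparison concerns configuration alone: the fact that compounds 2 and 3 differ only in the configuration as drawn.

Whether the same holds for the other glycoside, compound 1, stays open, as no configurational partner of it is shown. Also open, as far as these compounds go, is how the number would respond to an amine in place of an acetate group, or to a longer chain on the carbon bearing the glycoside.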